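Opening the amide ring toward a hydroxyethyl amide

The compounds below may be only part of what the source reports. "The series", "measured", "known", "first", "only" and "open" are said of these compounds alone.

Measured compounds:
Compound 1, `CCN(CC)C(=O)CC1CCc2cc(OC)c(OC)cc21`: 31.5%
Compound 2, `COc1cc2c(cc1OC)C(CC(=O)NC(C)C)CC2`: 37%
Compound 3, `COc1cc2c(cc1OC)C(CC(=O)N1CCCC1)CC2`: 22.2%

Of the compounds shown here, three with a shared core have been tested in a functional assay on the whole organism (strain Wistar) for inhibition, with Rattus norvegicus as the target, read by paw edema, with stated times of 60 min and 6 h, at a dose of 100 mg/kg by the oral route; a lower number here means less inhibition, a higher number more inhibition at the dose given (going by the name of the read-out); they differ only in the amine joined to the carbonyl carbon. Compound 3 gives the lowest of the three numbers, but not clearly the lowest inhibition in this assay: the step of a number 9.3 percentage points lower from compound 1 to compound 3 (within the scatter) lies within the scatter, so compound 1 and compound 3 cannot be ranked, while the step of a number 14.8 percentage points lower from compound 2 to compound 3 (beyond the scatter) lies beyond it.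

The next compound, compound 4, `COc1cc2c(cc1OC)C(CC(=O)NCCO)CC2`, changes this same position: (2-hydroxyethyl)amino in place of pyrrolidin-1-yl on a carbonyl carbon. For the measured compounds named here, the step that bears most on it is the one from compound 2 to compound 3, where a group with no ring gave way to pyrrolidin-1-yl and the number fell by a modest, real amount; compound 4 moves back toward a group with no ring. The step of a number 5.5 percentage points higher from compound 1 to compound 2 (within the scatter) shows that differences among such groups can also stay within the scatter. A modest rise is therefore expected, with wide uncertainty. Compound 4 is expected to give about 33% in this assay, between 20% and 46%. This estimate means an expected step of a number 10.8 percentage points higher from compound 3 to compound 4 (beyond the scatter).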

Compound 4, a percentage reported as inhibition, in the whole organism at one dose (the size of the read-out at that dose, not a potency): 13%
For compound 4 the middle estimate is 20 percentage points above the measured one; measured number below the stated range.
By their numbers in this assay, from the lowest: compounds 4, 3, 1 and 2 (each within the scatter of the next, the first and the last beyond it).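

In this assay, removing the ring does not by itself bring the number back up: the change to (2-hydroxyethyl)amino gives (a number 9.2 percentage points lower from compound 3 to compound 4 (within the scatter)), so these two compounds cannot be ranked. The larger difference lies among the groups with no ring, since 2-hydroxyethyl in place of isopropyl on an amide-type nitrogen gives (a number 24 percentage points lower from compound 2 to compound 4 (beyond the scatter)), and (2-hydroxyethyl)amino in place of diethylamino gives (a number 18.5 percentage points lower from compound 1 to compound 4 (beyond the scatter)); at this position, then, the number depends on what the chain carries and not simply on whether a ring is present. Nothing measured here explains why the hydroxyethyl amide falls so far from these two open-chain amides.

The compounds shown cannot separate the part played by the hydroxyl group from that of the short chain carrying it, and a plain ethyl or a 2-methoxyethyl group on the same nitrogen would address that question. Also open, as far as these compounds go, is how a longer 3-hydroxypropyl chain, a 2-aminoethyl group or a carboxylic acid at the end of the chain would read at this single dose.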